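A few compounds are considered here, and "the series" means these few. Any claim that something is new, unique, unknown or untested is made for them only; others in the source may bear on it.

Measured compounds:
Compound 1 `Cc1cn2cc(-c3cc4ccc(N5CCN(C)CC5)cc4oc3=O)nc2cn1`: in an ADME assay on a cell-free system (plasma, Homo sapiens) for protein binding, compound 1 gives 97%.
Compound 2 `Cc1cn2nc(-c3cc(=O)n4cc(N5CCNCC5)ccc4n3)cc2c(C)n1`: in this assay compound 2 gives 70%.

Of these two values, compound 2 has the larger unbound fraction; compound 1 lies a good way from it, and that gap is beyond the usual scatter. Compound 3 `Cc1cn2nc(-c3cc(=O)n4cc(N5CCN(C)CC5)ccc4n3)cc2c(C)n1` has not yet been measured. It differs from compound 2 only by methyl in place of hydrogen on an amine nitrogen in a ring. For the measured compounds named here, no measured pair shows this change on its own, so there is no direct comparison to lean on. The step in this assay is expected to be small, toward more binding, estimated as a 1.5-fold lower unbound fraction from compound 2 to compound 3 (0.18 log units; within the scatter). Compound 3 is expected to give about 80%, likely between 65% and 92%.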

Compound 3, plasma protein binding: 80%
Estimate against measurement, compound 3: no gap at the digits printed, within the range that was stated.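

For the compounds shown here, replacing piperazin-1-yl with 4-methylpiperazin-1-yl gives a 1.5-fold lower unbound fraction from compound 2 to compound 3 (0.18 log units; within the scatter) in this assay and so provides the first direct reading of this change. At this amine nitrogen in the ring, adding one methyl leaves plasma protein binding within the scatter. No measurement shown explains this small step. As far as these compounds go, whether a longer chain such as propyl or an acyl group such as acetyl on this nitrogen would shift binding further remains open. So does whether the same methyl change would behave alike on the core of compound 1.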